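A few compounds are considered here, and "the series" means these few. Any claim that something is new, unique, unknown or untested is made for them only; others in the source may bear on it.

Compound 1 `c1cc(Nc2nccc(-c3ccco3)n2)cc(-n2ccnc2)c1` gives 800 nM in a functional assay for inhibition, with Homo sapiens as the target; on this read-out lower numbers stand for stronger inhibition and higher numbers for weaker inhibition.
Compound 2 `c1ccc(Nc2nccc(-c3ccncc3)n2)cc1` gives 900 nM in this assay.
Compound 3 `Cc1cc(-c2ccco2)nc(Nc2ccccc2)n1` gives 17700 nM in this assay.

Among these three, compound 3 stands at the highest number, and its distance to the other two is well beyond the scatter of repeated measurements: compound 2 sits at a far lower number, and compound 1 is further still. Compound 1 and compound 2, on the other hand, lie within the scatter of each other, so nothing can be said about their order.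

Compound 4 `c1ccc(Nc2nccc(-c3ccco3)n2)cc1` has not yet been measured. It differs from compound 3 in a single spot: hydrogen in place of methyl on an aromatic carbon. In everything else the two share the same core and the same side groups.

For the measured compounds named here, no measured pair shows this exact change, so its effect must be guessed from the surroundings. Compound 4 resembles compound 1 and compound 2 in that it carries no methyl on the ring, and both of those give low numbers. On that basis the number for compound 4 is expected to drop clearly, a step of a 12-fold lower number from compound 3 to compound 4 (1.07 log units; beyond the scatter), well beyond the scatter. The estimate for compound 4 in this assay is therefore 1500 nM, with a range from 400 nM to 6000 nM.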

Compound 4, half-maximal inhibitory concentration: 32000 nM
Compound 4: the middle estimate sits 21-fold (1.33 log units) below what was measured; the measured number lies above the stated range.
By their numbers in this assay, from the lowest: compounds 1 and 2 (each within the scatter of the next); then compounds 3 and 4 (each within the scatter of the next).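

Compound 3 and compound 4 differ only in methyl or hydrogen on the aromatic carbon next to the ring nitrogen, and in this assay this change gives a 1.8-fold higher number from compound 3 to compound 4 (0.26 log units; within the scatter), so here the methyl does not separate the two compounds. The low numbers of compound 1 and compound 2 therefore cannot be credited to the missing methyl, since compound 4 lacks it too and still sits far from both. The large differences appear at the other places instead: furan-2-yl in place of pyridin-4-yl gives a 36-fold higher number from compound 2 to compound 4 (1.55 log units; beyond the scatter) on the same shared core, and hydrogen in place of 1H-imidazol-1-yl gives a 40-fold higher number from compound 1 to compound 4 (1.60 log units; beyond the scatter) in this comparison.

Nothing shown explains why these two changes count for so much while the methyl does not. Going by these compounds, it also stays open whether a longer chain such as ethyl, or an amine, on the aromatic carbon that held the methyl would leave the number just as unmoved, or whether only a group as small as methyl passes without a clear effect.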